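Hydroxyalkyl-alkyne variants of the nitro core: cytotoxicity notes

The source may hold more compounds than are shown below. What is called first, only, known or untested is meant among the compounds shown, and "the series" means these compounds.

Measured so far:
compound 1, `O=[N+]([O-])c1c(CS(=O)(=O)c2ccccc2)nc2c(C#Cc3cccc(F)c3)cc(Cl)cn12`: > 3900 nM
compound 2, `O=[N+]([O-])c1c(CS(=O)(=O)c2ccccc2)nc2c(C#CCOc3ccccc3)cc(Cl)cn12`: 8400 nM
compound 3, `CC(C)(O)C#Cc1cc(Cl)cn2c([N+](=O)[O-])c(CS(=O)(=O)c3ccccc3)nc12`: > 62500 nM

In an ADME assay on HepG2 cells (Homo sapiens) for cytotoxicity, read by MTT assay, with a stated time of 72 h (a lower number here means that less compound is tolerated, a higher number that more compound is tolerated), compound 1 gives only a limit, > 3900 nM. Compound 3 likewise gives only a limit, > 62500 nM. Compound 2 gives a number, 8400 nM. Hence a step that the limit leaves unreadable from compound 1 to compound 2 and a step that the two limits leave unreadable from compound 1 to compound 3; only an at least 7.4-fold higher number from compound 2 to compound 3 (0.87 log units; beyond the scatter) is readable, and it points toward the tertiary alcohol being better tolerated.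

Compound 4, `O=[N+]([O-])c1c(CS(=O)(=O)c2ccccc2)nc2c(C#CC3(O)CCCCC3)cc(Cl)cn12`, differs from compound 1 by 1-hydroxycyclohexyl in place of 3-fluorophenyl on a triple-bonded carbon. This mirrors the change that gives compound 3 its limit, (the limit of > 62500 nM in this assay, at which 1 of the 3 values shown sits), so in this assay the step that the limit leaves unreadable from compound 1 to compound 4 is expected to run toward a higher number. Compound 4 is expected near 50000 nM, within 10000 nM to 200000 nM, quite possibly reported only as a limit.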

Compound 4, half-maximal cytotoxic concentration: > 25000 nM
Compound 4 was reported as a limit (the forecaster's own chance of this, stated with the estimate: 60%); the middle value is on the limit's open side.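

The change to 1-hydroxycyclohexyl gives an at least 2.9-fold higher number from compound 2 to compound 4 (0.47 log units; beyond the scatter) in this assay, so the higher number seen with 1-hydroxy-1-methylethyl is no longer tied to that one group. A six-membered carbon ring on the triple-bonded carbon, here non-aromatic and carrying a hydroxyl, also stays clear of the number of compound 2. The steps from compound 1 and from compound 3 to compound 4 cannot be read, since limits stand on both sides.

Any order between the two hydroxyl-bearing groups remains open. So does the outcome for an amine, a carboxylic acid or a longer hydroxyalkyl chain at this position.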